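Swapping one aryl group on a poorly stable compound

The compounds below may be only part of what the source reports. "The series", "measured", "known", "first", "only" and "open" are said of these compounds alone.

In an ADME assay (liver) for metabolic stability, with Liver microsome (Rattus norvegicus) as the target, read by LC-MS, using microsomes, with a stated time of 30 min, tested at 4 uM (on this read-out lower numbers stand for a less stable compound and higher numbers for a more stable compound), compound 2 (`Cc1nc(N2CCN(C)CC2)c2nc(-c3cccc(C(F)(F)F)c3)n(C3CCOCC3)c2n1`) gives 28% and so holds the lower of the two numbers available. The other measured compound, compound 1 (`CCN1CCN(c2nc(C)nc3c2nc(-c2ccccc2Cl)n3CC2CCOCC2)CC1`), gives 80% and that gap lies beyond the scatter. For the measured compounds named here, these two compounds differ in more than one place, so their gap cannot be tied to any single group, and no measured pair isolates a one-place change.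

Compound 3 (`CCc1ccccc1-c1nc2c(N3CCN(C)CC3)nc(C)nc2n1C1CCOCC1`) differs from compound 2 in one place, with 2-ethylphenyl in place of 3-(trifluoromethyl)phenyl on an aromatic carbon. Going by the values given here, with no measured step to guide it, the expectation stays cautious: the estimated change is a number 7 percentage points higher from compound 2 to compound 3 (within the scatter) and this small rise would stay within the scatter. For compound 3 the estimate is 35% with an expected range from 15% to 60% in repeat measurements.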

Compound 3, percent of the compound remaining: 51%
Compound 3: middle estimate off by 16 percentage points, on the low side; measured number inside the range.
By their numbers in this assay, from the lowest: compound 2; then compound 3; then compound 1.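

In this assay, for the compounds shown here, this is the first comparison here that changes only one place, and it shows that the aryl group on this aromatic carbon, next to the ring atom that bears an oxan-4-yl group, matters on its own: 2-ethylphenyl in place of 3-(trifluoromethyl)phenyl gives a number 23 percentage points higher from compound 2 to compound 3 (beyond the scatter). The rest of the molecule stays the same, so the rise belongs to this swap. Nothing available explains why the number rises.

The swap alters both the substituent and where it sits on the phenyl ring, so these two changes remain tangled. A 2-(trifluoromethyl)phenyl group or a 3-ethylphenyl group at this position would pull them apart, and a plain phenyl group would show what the unsubstituted ring gives.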